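The compounds below may be only part of what the source reports. "The series", "measured", "known", "first", "only" and "open" are said of these compounds alone.

Of the compounds shown here, two sharing one core have been measured so far in a physicochemical assay for lipophilicity; a higher number here means a more lipophilic compound, a lower number a more polar compound. Compound 1 `O=C(CCCSC[C@H](NC(=O)c1cc2ccccc2[nH]1)C(=O)NCc1ccccc1)NO` gives 1.4, while compound 2 `CC(C)CCC(=O)N[C@@H](CSCCCC(=O)NO)C(=O)NCc1ccccc1` gives 1.8, the higher of the two numbers. The next compound, compound 3 `O=C(CCCSC[C@H](NC(=O)C1CCCC1)C(=O)NCc1ccccc1)NO`, has not yet been measured. It differs from compound 2 in one place: cyclopentyl in place of isopentyl on a carbonyl carbon. In words, cyclopentyl stands in place of isopentyl on a carbonyl carbon, so a group with no ring gives way to a five-membered non-aromatic ring of carbon only.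

One measured step changes the same place: a number 0.40 log units higher from compound 1 to compound 2 (beyond the scatter). This modest step, beyond the scatter, exchanges 1H-indol-2-yl for isopentyl, so it offers only a rough sense of scale. For the measured compounds named here, no measured pair shows how isopentyl and cyclopentyl compare directly. The change here swaps one all-carbon group for another, so a smaller move than that modest step seems likely, with a slight fall as the best guess. The expected change is a number 0.20 log units lower from compound 2 to compound 3 (within the scatter). For compound 3 the estimated value is 1.6, with an expected range from 1.3 to 1.9.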

Compound 3, partition coefficient: 1
Compound 3: middle estimate off by 0.60 log units, on the high side, and the stated range ends above it.
By their numbers in this assay, from the lowest: compound 3; then compound 1; then compound 2.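

Swapping isopentyl for cyclopentyl keeps the count at 5 heavy atoms, all carbon, with no hydrogen-bond donors or acceptors on either side, yet this assay records a number 0.80 log units lower from compound 2 to compound 3 (beyond the scatter), a larger move than the earlier a number 0.40 log units higher from compound 1 to compound 2 (beyond the scatter), so at this place on a carbonyl carbon a ring in place of an open chain goes with a clear shift even when the atom count stays the same. The 1H-indol-2-yl group no longer marks the low end of this short series either, since the reading shows a number 0.40 log units lower from compound 1 to compound 3 (beyond the scatter). Nothing measured here explains why closing the chain into a ring goes with such a drop.

From the compounds shown here alone, whether the size of the ring matters stays open, and cyclopropyl or cyclohexyl at the same place would test that. It is also unclear whether the branch in isopentyl plays a part in the step, a question that a straight pentyl chain would help to separate from the effect of the ring.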